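From nitro to methoxy in an antiproliferative series

A few compounds are considered here, and "the series" means these few. Any claim that something is new, unique, unknown or untested is made for them only; others in the source may bear on it.

In a functional assay on HeLa cells (Homo sapiens) for antiproliferative activity, read by sulforhodamine B assay, with a stated time of 48 h (on this read-out higher numbers stand for weaker inhibition and lower numbers for stronger inhibition), compound 1 `COc1cc(C(=O)/C=C\Nc2ccc(-c3nc4cc(OC)c(OC)c(OC)c4s3)cc2)c(Br)c(OC)c1OC` gives 6600 nM and compound 2 `COc1cc(C(=O)/C=C\Nc2ccc(-c3nc4cc(OC)c(OC)c(OC)c4s3)cc2)cc([N+](=O)[O-])c1OC` gives 7800 nM on the same test. Compound 2 therefore stands level with compound 1: the two numbers lie within the usual scatter of repeated measurements, so they cannot be ranked.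

The next molecule, compound 3 `COc1cc(C(=O)/C=C\Nc2ccc(-c3nc4cc(OC)c(OC)c(OC)c4s3)cc2)cc(OC)c1OC`, differs from compound 2 in one place, with methoxy in place of nitro on an aromatic carbon. Among the measured compounds shown here, no measured pair yet shows what a single change of this kind does, so the expectation is a judgement and not a trend read from the data. In this assay a moderate shift toward a lower number, meaning stronger inhibition, seems the likeliest outcome, although a result within the scatter would be no surprise. As an estimate, the expected move is a 3.1-fold lower number from compound 2 to compound 3 (0.49 log units; beyond the scatter) and it carries wide uncertainty. The estimated value for compound 3 is 2500 nM with an expected range from 300 nM to 9000 nM until the measurement arrives.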

Compound 3, half-maximal inhibitory concentration: 5300 nM
Beside the measured number, compound 3's estimate is 2.1-fold (0.33 log units) below it; measured number inside the range.
By their numbers in this assay, from the lowest: compounds 3, 1 and 2 (each within the scatter of the next).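

In this assay, methoxy in place of nitro on this aromatic carbon, ortho to a methoxy group, gives a 1.5-fold lower number from compound 2 to compound 3 (0.17 log units; within the scatter), so these two groups cannot be told apart here, even though they differ in their atoms and in their count of hydrogen-bond acceptors. Among the compounds shown here, the other single change, hydrogen in place of bromo on an aromatic carbon, gives a 1.2-fold lower number from compound 1 to compound 3 (0.10 log units; within the scatter), so this pair also cannot be ranked, and the three compounds so far stand level on this test. Nothing available explains why these swaps leave the result within the scatter.

From the compounds shown here alone, only nitro and methoxy have been compared at this position, so it remains open whether a different group there, such as an amine, a carboxylic acid or a longer alkoxy chain, would move the number beyond the scatter. Going by these compounds, it is also open whether the flat result holds only for these compounds or would also appear with a change elsewhere on the shared core.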